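Working notes: compound 3 to compound 4, solubility

The source may report more compounds than this note shows. Statements on the series, on what has been measured and on what is new or still open speak of the compounds shown alone.

Three compounds of the series have a number in a physicochemical assay for solubility, in phosphate buffer, measured as kinetic solubility, with a stated time of 1 h, at pH 7.4; a lower number here means a less soluble compound, a higher number a more soluble compound. Compound 1 `Cc1cc(C)cc(NC(=O)COc2cc(C)nc3ccc(Cl)cc23)c1` gives 8000 nM, compound 2 `Cc1cc(C)cc(NC(=O)COc2cc(C)nc3ccc(C)cc23)c1` gives 83000 nM, and compound 3 `COc1ccc2nc(C)cc(OCC(=O)Nc3c(C)cccc3C)c2c1` gives 112000 nM. Compound 3 stands highest of the three: its gap to compound 2 is within the scatter, while its gap to compound 1 is beyond it. Within the data shown here, the only step between measured compounds that differ in one place is a 10-fold higher number from compound 1 to compound 2 (1.02 log units; beyond the scatter), a change on the shared core rather than on the amide side.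

Compound 4 `COc1ccc2nc(C)cc(OCC(=O)Nc3cccnc3)c2c1` is not yet measured in this assay. It differs from compound 3 by pyridin-3-yl in place of 2,6-dimethylphenyl on an amide-type nitrogen. Among the measured compounds shown here, no measured step bears on this change: the one recorded step concerns a substituent on the core, and both compound 2 and compound 3 carry the same 2,6-dimethylphenyl on the amide-type nitrogen as compound 1. Compound 3 alone therefore anchors the expectation.

With nothing in the series to set the direction, the expected step of a 1.6-fold higher number from compound 3 to compound 4 (0.21 log units; within the scatter) is taken as small, and compound 4 is estimated at 180000 nM in this assay, with a range from 70000 nM to 450000 nM, the uncertainty reflecting the absence of any comparable measured step.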

Compound 4, solubility: 32000 nM
Compound 4: the middle estimate sits 5.6-fold (0.75 log units) above what was measured; measured number outside the range, below it.
By their numbers in this assay, from the lowest: compound 1; then compound 4; then compounds 2 and 3 (each within the scatter of the next).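

In this assay, among these compounds, the group on the amide-type nitrogen now has a step of its own: pyridin-3-yl in place of 2,6-dimethylphenyl gives a 3.5-fold lower number from compound 3 to compound 4 (0.54 log units; beyond the scatter) and lies beyond the scatter, so a change at this position, and not only the one on the shared core in a 10-fold higher number from compound 1 to compound 2 (1.02 log units; beyond the scatter), separates compounds in this read-out. The lower number comes with a group of 6 heavy atoms and 1 hydrogen-bond acceptor replacing one of 8 heavy atoms and 0 hydrogen-bond acceptors, so a hydrogen-bond acceptor on this ring does not go with a higher number in this single pair. No measurement at hand accounts for the step.

A single step changes the ring atoms and removes both methyl groups at once, and a plain phenyl on the amide-type nitrogen would be needed to tell these two differences apart. On these data alone, how a group of a different kind at this position, such as a carboxylic acid or an aminoalkyl chain, would read in this assay remains open, as does whether this step keeps its size with the other substituents on the shared core.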